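This account rests on a few compounds, and the source may have more. Where it says the series, first, only, none or still open, it means among the compounds named here.

Compound 1 `COc1cc(CCC(=O)OCCc2ccc(O)c(O)c2)ccc1O` gives 29500 nM. Compound 2 `CC(=O)Oc1cc(CCOC(=O)CCc2ccc(O)c(OC(C)=O)c2)ccc1O` gives 26800 nM. Compound 3 `CC(=O)Oc1ccc(CCOC(=O)CCc2ccc(OC(C)=O)c(OC(C)=O)c2)cc1OC(C)=O` gives 37300 nM.

All three were measured in a functional assay on U-251 cells (Homo sapiens) for inhibition, read by sulforhodamine B assay, with a stated time of 72 h; a higher number here means a weaker inhibitor, a lower number a stronger inhibitor. Compound 1 has the second highest of the three numbers; its nearest neighbour is compound 2, and the two lie within the scatter of each other. Among the measured compounds shown here, compound 3 stands furthest from compound 1, yet this gap too is within the scatter, so no compound can be ranked against another on these numbers.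

The step under consideration leads from compound 1 to compound 4 `O=C(CCc1ccc(O)c(O)c1)OCCc1ccc(O)c(O)c1`. The change is hydrogen in place of methyl on an oxygen on an aromatic ring. For the measured compounds named here, no step between two measured compounds reproduces this change, so the expectation rests on the narrow spread of the three measured numbers: compounds 1, 2 and 3 differ widely in their pattern of hydroxy and acetyl groups yet give numbers within the scatter of each other. It is therefore expected that the step of a 1.2-fold lower number from compound 1 to compound 4 (0.07 log units; within the scatter) in this assay will be none beyond the scatter. Compound 4 is estimated at 25000 nM with a range from 10000 nM to 60000 nM.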

Compound 4, half-maximal inhibitory concentration: 24300 nM
Beside the measured number, compound 4's estimate is 1.0-fold (0.01 log units) above it; measured number inside the range.
By their numbers in this assay, from the lowest: compounds 4, 2, 1 and 3 (each within the scatter of the next).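

In this assay, among the compounds shown here, the exchange of methoxy for hydroxy, with hydrogen in place of methyl on an oxygen on an aromatic ring, gives a 1.2-fold lower number from compound 1 to compound 4 (0.08 log units; within the scatter) as the only step here that isolates a single place. The earlier compounds shown here differed from one another in more than one place, so their similar numbers could not speak for any one group, whereas this pair shows that removing this methyl alone leaves the number within the scatter. Nothing measured here bears on why this is so.

The compounds shown leave open whether a longer chain on this oxygen, such as ethyl or benzyl, or an amine in its place, would give a number beyond the scatter. They also leave open whether the same exchange would stay within the scatter if an amide replaced the ester of the shared core.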